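The compounds below may be only part of what the source reports. "The series", "measured", "known", "first", "only" and "open" are said of these compounds alone.

Of the compounds shown here, three built on the same shared core have so far been measured in a functional assay on MIA PaCa-2 cells (Homo sapiens) for inhibition, read by MTT assay, with a stated time of 72 h; on this read-out higher numbers stand for weaker inhibition of growth and lower numbers for stronger inhibition of growth. Compound 1 `O=S(=O)(NCCCCCCNCc1ccc(Br)cc1)c1ccccc1F` gives 13300 nM. Compound 2 `O=S(=O)(NCCCCCCNCc1ccc(Br)cc1)c1ccc2ccsc2c1` gives 6000 nM. Compound 3 `O=S(=O)(NCCCCCCNCc1ccc(Br)cc1)c1ccc(Cl)cc1` gives 5900 nM, the lowest number of the three, although its gap to compound 2 lies within the scatter, so these two cannot be ordered; against compound 1 it stands apart by a 2.3-fold lower number from compound 1 to compound 3 (0.35 log units; beyond the scatter), and compound 2 likewise stands apart from compound 1 by a 2.2-fold lower number from compound 1 to compound 2 (0.35 log units; beyond the scatter).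

Compound 4 `Cc1ccc(S(=O)(=O)NCCCCCCNCc2ccc(Br)cc2)cc1` differs from compound 3 by methyl in place of chloro on an aromatic carbon. The measured steps that bear on this change are the ones that alter the group on the sulfonyl sulfur: a 2.3-fold lower number from compound 1 to compound 3 (0.35 log units; beyond the scatter) and a 1.0-fold lower number from compound 2 to compound 3 (0.01 log units; within the scatter). Among the compounds with values here, the second of these shows that two rather different groups on that sulfur can give numbers within the scatter of each other, and the first that a change on this part of the molecule can move the number by a modest amount. Methyl in place of chloro on the same aromatic carbon, para to a large group, is a smaller alteration than either of those, so no step beyond the scatter is expected in this assay, with at most a slight lean toward a higher number.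

Compound 4 is therefore expected to give 7000 nM, within a range of 3000 nM to 17000 nM. This estimate corresponds to an expected step of a 1.2-fold higher number from compound 3 to compound 4 (0.07 log units; within the scatter).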

Compound 4, concentration for 50% growth inhibition: 12300 nM
Beside the measured number, compound 4's estimate is 1.8-fold (0.24 log units) below it, within the range that was stated.
By their numbers in this assay, from the lowest: compounds 3 and 2 (each within the scatter of the next); then compounds 4 and 1 (each within the scatter of the next).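

In this assay, going from 4-chlorophenyl to 4-methylphenyl exchanges one heavy atom for one heavy atom on an aromatic carbon para to a large group, with no hydrogen-bond donor or acceptor entering or leaving, yet it gives a 2.1-fold higher number from compound 3 to compound 4 (0.32 log units; beyond the scatter), so even a change this small at this position can move the number beyond the scatter. The 4-methylphenyl group also stands apart from 1-benzothiophen-6-yl, with a 2.1-fold higher number from compound 2 to compound 4 (0.31 log units; beyond the scatter), but cannot be told apart from 2-fluorophenyl, with a 1.1-fold lower number from compound 1 to compound 4 (0.03 log units; within the scatter), so compound 3 and compound 2 now form one pair of numbers and compound 4 and compound 1 another. Nothing measured here accounts for this step.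

From the compounds shown here alone, whether the lower number belongs to chloro in particular or would also appear with other groups on the same aromatic carbon stays open, and bromo, fluoro, methoxy or trifluoromethyl there would begin to settle it. Going by these compounds, all four compounds share the same core, so whether the step between chloro and methyl would persist with a longer chain in that core also remains unknown.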